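Trimming the Chain of Compound 1

The compounds below may be only part of what the source reports. "The series", "measured", "known", "first", "only" and "open" are said of these compounds alone.

In a functional assay on the whole organism (S2 cells, strain S2) for inhibition, with Drosophila as the target, read by a luciferase reporter, with stated times of 1.5 h and 8 h (a lower number here means a stronger inhibitor, a higher number a weaker inhibitor), compound 1 (`CCCCCCCC(=O)c1c(OC)c(Cl)c(OC)c(Cl)c1OC`) gives 15300 nM. This is the higher of the two numbers available, so it is the weaker inhibitor of the pair. Compound 2 (`CCCCCC(=O)c1c(O)cc(OC)c(Cl)c1O`) gives 4600 nM, and the gap between them lies beyond the usual scatter.

Compound 3 (`CCCCC(=O)c1c(OC)c(Cl)c(OC)c(Cl)c1OC`) keeps the core of compound 1 and differs at one place on the chain: hydrogen in place of propyl on a saturated chain carbon, four bonds along the chain from a carbonyl carbon, on a saturated chain carbon, four bonds along the chain from a carbonyl carbon. For the measured compounds named here, no pair of measured compounds shows this change on its own, so the data give no direct guide to its size or direction. In this assay, no step beyond the scatter is expected, and the estimated step of a 1.3-fold lower number from compound 1 to compound 3 (0.11 log units; within the scatter) reflects this. Compound 3 is expected to give about 12000 nM, with an estimated range of 4500 nM to 30000 nM.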

Compound 3, half-maximal inhibitory concentration: 23500 nM
Compound 3: the middle estimate sits 2.0-fold (0.29 log units) below what was measured; measured number inside the range.
By their numbers in this assay, from the lowest: compound 2; then compounds 1 and 3 (each within the scatter of the next).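

Hydrogen in place of propyl on a saturated chain carbon, four bonds along the chain from a carbonyl carbon, now has its first direct reading: in this assay the step is a 1.5-fold higher number from compound 1 to compound 3 (0.19 log units; within the scatter) and lies within the scatter. With the core of compound 1 kept, this single pair therefore gives no sign that propyl at this place matters to the read-out, though one pair cannot set a trend. Nothing measured here bears on why the two numbers stay so close.

From the compounds shown here alone, whether a longer chain, an amine or a carboxylic acid at this carbon would also stay within the scatter remains open. So does whether the same change would give a similar step on the core of compound 2.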